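From an Amine to an Amide on the Ring Nitrogen

This account rests on a few compounds, and the source may have more. Where it says the series, first, only, none or still open, it means among the compounds named here.

Compound 3 `CCCCN1CCc2nc(C#Cc3ccccc3)sc2C1` has been tested in an assay on HEK293 cells for negative allosteric modulation of metabotropic glutamate receptor 5 (Homo sapiens), read by FLIPR, with a stated time of 1 h; on this read-out lower numbers stand for stronger inhibition and higher numbers for weaker inhibition. In this assay compound 3 gives > 10000 nM, which is a limit of the assay and not a number. Compound 2 `CN1CCc2nc(C#Cc3cccc(F)c3)sc2C1` also reaches only a limit, > 10000 nM, in this assay. The single numbered result comes from compound 1 `O=C1c2sc(C#Cc3ccccc3)nc2CN1C1CC1`, which gives 23 nM in this assay and carries a carbonyl on its ring nitrogen. Going by the values given here, the situation is summed up by the limit of > 10000 nM in this assay, at which 2 of the 3 values shown sit; no step between measured compounds can be drawn, so compound 3 stands at the limit and nowhere more precise.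

Compound 4 `CCC(=O)N1CCc2nc(C#Cc3ccccc3)sc2C1` differs from compound 3 by propanoyl in place of butyl on an amine nitrogen in a ring. Because compound 1 gives 23 nM with a carbonyl on its ring nitrogen, a move toward stronger inhibition is expected, an at least 16-fold lower number from compound 3 to compound 4 (1.22 log units; beyond the scatter), though its size is uncertain. For compound 4 the estimate in this assay is 600 nM, between 50 nM and 8000 nM.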

Compound 4, half-maximal inhibitory concentration: 38 nM
Estimate against measurement, compound 4: 16-fold (1.20 log units) above; the measured number lies below the stated range.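

In this assay, going by these compounds alone, the pair gives the first step at this ring nitrogen, with propanoyl in place of butyl producing an at least 260-fold lower number from compound 3 to compound 4 (2.42 log units; beyond the scatter). Butyl and propanoyl each hold 4 heavy atoms, so this step separates the two groups at an equal heavy-atom count, with the oxygen and its double bond being what enters. The true size of the step remains unknown because one end of it rests on a limit of the assay and not on a number: the limit of > 10000 nM in this assay, at which 2 of the 4 values shown sit.

On these data alone, whether a similar result would hold for an acetyl group, a longer acyl chain or a sulfonyl group on this nitrogen stays open. As far as these compounds go, it is also open whether a urea at the same place would behave like propanoyl.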